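Thioamide Swap at the Pyrrolidine of a V2 Agonist Series

A few compounds are considered here, and "the series" means these few. Any claim that something is new, unique, unknown or untested is made for them only; others in the source may bear on it.

Measured so far:
compound 1, `CCOC(=O)CNC(=O)NCc1ccc(C(=O)N2CCCCc3ccccc32)cc1C`: 140 nM
compound 2, `COC(=O)[C@@H]1CCCN1C(=O)NCc1ccc(C(=O)N2CCCCc3ccccc32)cc1C`: 100 nM
compound 3, `CCN(CC)C(=O)[C@@H]1CCCN1C(=O)NCc1ccc(C(=O)N2CCCCc3ccccc32)cc1C`: 350 nM

In a functional assay on HEK293 cells for agonist activity at Vasopressin V2 receptor (Homo sapiens), read by a luciferase reporter and cAMP accumulation (a higher number here means that more compound is needed for the effect, a lower number that less compound is needed), compound 3 gives the highest number of the three; the nearest is compound 1 and the furthest is compound 2, with a 2.5-fold higher number from compound 1 to compound 3 (0.40 log units; beyond the scatter) and a 3.5-fold higher number from compound 2 to compound 3 (0.54 log units; beyond the scatter) both beyond the usual scatter, so compound 3 is the weakest of the measured compounds in this assay.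

Compound 4, `Cc1cc(C(=O)N2CCCCc3ccccc32)ccc1CNC(=O)N1CCC[C@H]1C(=S)N(C)C`, differs from compound 3 in one place: a group of 5 heavy atoms (3 carbon, 1 nitrogen, 1 sulfur; no ring) in place of a group of 7 heavy atoms (5 carbon, 1 nitrogen, 1 oxygen; no ring), on a saturated ring carbon. Within the data shown here, no measured step exchanges oxygen for sulfur, so the bearing steps are indirect. a 3.5-fold higher number from compound 2 to compound 3 (0.54 log units; beyond the scatter) shows that replacing methoxy with diethylamino cost potency, and a 2.5-fold higher number from compound 1 to compound 3 (0.40 log units; beyond the scatter) points the same way; compound 4 keeps a nitrogen-bearing group at that carbon but a smaller one. A step back toward the numbers of compounds 1 and 2 is therefore plausible but uncertain, and the expected step of a 1.4-fold lower number from compound 3 to compound 4 (0.15 log units; within the scatter) is modest.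

The estimate for compound 4 is 250 nM, with a range from 90 nM to 700 nM.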

Compound 4, half-maximal effective concentration: 3.2 nM
Compound 4: middle estimate off by 78-fold (1.89 log units), on the high side, and the stated range ends above it.
By their numbers in this assay, from the lowest: compound 4; then compounds 2 and 1 (each within the scatter of the next); then compound 3.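

In this assay, the earlier change on this saturated ring carbon moved the number only modestly, whereas the group with sulfur brings a 110-fold lower number from compound 3 to compound 4 (2.04 log units; beyond the scatter), the largest step in the series. This is more than a return to the level of the esters, with a 31-fold lower number from compound 2 to compound 4 (1.49 log units; beyond the scatter) and a 44-fold lower number from compound 1 to compound 4 (1.64 log units; beyond the scatter). The position can therefore carry far more potency than compounds 1, 2 and 3 suggested.

As far as these compounds go, compound 4 differs from compound 3 both in sulfur for oxygen and in methyl for ethyl on the nitrogen, so the share of each change stays open, and a dimethylcarbamoyl group on this carbon would separate them. No available measurement explains why the number falls so far.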